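The source may hold more compounds than are shown below. What is called first, only, known or untested is meant among the compounds shown, and "the series" means these compounds.

In a functional assay on HCT-8 cells (Homo sapiens) for antiproliferative activity, read by sulforhodamine B assay, with a stated time of 48 h (a lower number here means a stronger inhibitor, a higher number a weaker inhibitor), compound 1 `COc1ccc(/C=C/C(=O)c2ccccc2-c2ccc(F)cc2)cc1` gives 220 nM. Going by the values given here, the only other measured compound, compound 2 `CN(C)c1ccc(/C=C/C(=O)c2ccccc2-c2ccc(F)cc2)cc1`, gives 130 nM, so compound 1 stands level with it within the scatter. The unmeasured compound 3 `COc1ccc(/C=C/C(=O)c2ccccc2-c2cccc(F)c2)cc1` keeps the core of compound 1 and differs from it by 3-fluorophenyl in place of 4-fluorophenyl on an aromatic carbon. Among the compounds with values here, only one measured step exists, a 1.7-fold lower number from compound 1 to compound 2 (0.23 log units; within the scatter). Within the data shown here, it concerns dimethylamino in place of methoxy, a different group, so it bears on this change only indirectly, and the data hold no measured step for a change of the fluorophenyl group. No shift beyond the scatter is therefore expected in this assay, and the expected step is a 1.1-fold higher number from compound 1 to compound 3 (0.06 log units; within the scatter). For compound 3 the estimated value is 250 nM, with an expected range from 90 nM to 600 nM.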

Compound 3, half-maximal inhibitory concentration: 200 nM
Compound 3: the middle estimate sits 1.3-fold (0.10 log units) above what was measured; the range from low to high includes it.
By their numbers in this assay, from the lowest: compounds 2, 3 and 1 (each within the scatter of the next).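

In this assay the exchange of 4-fluorophenyl for 3-fluorophenyl gives a 1.1-fold lower number from compound 1 to compound 3 (0.04 log units; within the scatter), so this assay does not separate the two fluorophenyl groups on the core of compound 1. The earlier pair differed only at the methoxy and dimethylamino place and so said nothing about the fluorophenyl group, whereas this step shows that moving the fluorine within that group leaves the reading unchanged within the scatter. Nothing available here explains why the two groups read alike.

As far as these compounds go, what stays open is whether this tolerance extends to other groups on that ring, such as a chlorine, a trifluoromethyl, an amine or a carboxylic acid in place of the fluorine. From the compounds shown here alone, it also remains open whether 3-fluorophenyl would read the same alongside the dimethylamino group of compound 2.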